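The source may report more compounds than this note shows. Statements on the series, on what has been measured and on what is new or still open speak of the compounds shown alone.

Among the compounds with values here, compound 1 `COc1ccc(CN(C(=O)CSc2nc3ccccc3s2)c2cc(OC)c(OC)c(OC)c2)cc1` is one of two compounds measured in a functional assay on PC-3 cells (Homo sapiens) for antiproliferative activity, read by MTT assay, with a stated time of 48 h; a lower number here means a stronger inhibitor, a higher number a weaker inhibitor. In this assay compound 1 gives 8460 nM, the lowest of the two numbers, though compound 2 `COc1ccc(CN(C(=O)CSc2nc3cc(Cl)ccc3s2)c2cc(OC)c(OC)c(OC)c2)cc1O` gives 11200 nM, which lies within the scatter of that figure. Compound 3 `COc1ccc(CN(C(=O)CSc2nc3ccccc3s2)c2cc(OC)c(OC)c(OC)c2)cc1F` differs from compound 1 by a single change: fluoro in place of hydrogen on an aromatic carbon. Within the data shown here, with no measured step between two compounds available that isolates such a change, a small move in this assay is expected, none beyond the scatter, so the step from compound 1 to compound 3 is estimated at a 1.1-fold lower number from compound 1 to compound 3 (0.02 log units; within the scatter). For compound 3 the expected value is 8000 nM, with a range from 4000 nM to 16000 nM.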

Compound 3, half-maximal inhibitory concentration: 20100 nM
Compound 3: the middle estimate sits 2.5-fold (0.40 log units) below what was measured, and the stated range ends below it.
By their numbers in this assay, from the lowest: compounds 1, 2 and 3 (each within the scatter of the next, the first and the last beyond it).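

In this assay, going from 4-methoxyphenyl to 3-fluoro-4-methoxyphenyl gives a 2.4-fold higher number from compound 1 to compound 3 (0.38 log units; beyond the scatter), the only step among these compounds that isolates one change. It shows that this position, ortho to a methoxy group, is not indifferent to fluoro in place of hydrogen: the change weakens inhibition modestly. No measurement at hand explains this loss. As far as these compounds go, whether an amine, a methyl or a nitrile at this position would also weaken inhibition remains open. So does whether fluoro would have the same effect elsewhere on this ring.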